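This account rests on a few compounds, and the source may have more. Where it says the series, first, only, none or still open, it means among the compounds named here.

Compound 1 `COc1ccccc1-c1cc(C2CCNC2)ccc1Cl`: 3.4 nM
Compound 2 `COc1ccccc1-c1cc(C2CCN(C)C2)ccc1Cl`: 19 nM
Compound 3 `CNCc1ccc(Cl)c(-c2ccccc2OC)c1`: 1200 nM

All three were tested in an assay on isolated protein for binding affinity to 5-hydroxytryptamine receptor 1D (Homo sapiens); a lower number here means a stronger inhibitor, a higher number a weaker inhibitor. Compound 3 gives the highest number of the three and is therefore the weakest binder here: the two steps leading to it are a 63-fold higher number from compound 2 to compound 3 (1.80 log units; beyond the scatter) and a 350-fold higher number from compound 1 to compound 3 (2.55 log units; beyond the scatter), both large and well beyond the scatter.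

Compound 4 `COc1ccccc1-c1cc(CN(C)C)ccc1Cl` is not yet measured. It differs from compound 3 in one place only: methyl in place of hydrogen on an amine nitrogen. Among the measured compounds shown here, the one measured step that speaks to this change runs from compound 1 to compound 2, where the same swap of methyl for hydrogen on an amine nitrogen in a ring gave a 5.6-fold higher number from compound 1 to compound 2 (0.75 log units; beyond the scatter), a modest weakening. For the measured compounds named here, in compound 3 the amine nitrogen is not in a ring; its other neighbours are two saturated chain carbons, so the carry-over is not certain, and only one such step exists to lean on. Still, the direction it points is toward a higher number, and a modest step is expected, a 3.3-fold higher number from compound 3 to compound 4 (0.52 log units; beyond the scatter). Compound 4 is therefore estimated to give 4000 nM in this assay, with a likely range from 1500 nM to 12000 nM.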

Compound 4, inhibition constant: 1300 nM
Compound 4: the middle estimate sits 3.1-fold (0.49 log units) above what was measured; measured number below the stated range.
By their numbers in this assay, from the lowest: compound 1; then compound 2; then compounds 3 and 4 (each within the scatter of the next).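

In this assay, methyl in place of hydrogen on the chain amine nitrogen changes essentially nothing, with a 1.1-fold higher number from compound 3 to compound 4 (0.03 log units; within the scatter), whereas the same swap on the ring nitrogen gave a 5.6-fold higher number from compound 1 to compound 2 (0.75 log units; beyond the scatter), so in these two pairs the cost of this methyl is not the same on a chain nitrogen as on a ring nitrogen. Adding the methyl also leaves the chain amine far behind both ring amines, with a 68-fold higher number from compound 2 to compound 4 (1.84 log units; beyond the scatter) and a 380-fold higher number from compound 1 to compound 4 (2.58 log units; beyond the scatter), so among these compounds, the large losses go with replacing the ring, whether the chain nitrogen carries one methyl or two. Nothing available explains why the methyl matters on the ring nitrogen but not on the chain nitrogen.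

The compounds shown leave open whether a larger group on the chain nitrogen, such as ethyl, would be tolerated as well as methyl, and how the unsubstituted aminomethyl group would compare with compound 3. They also leave open whether a longer chain, such as 2-(methylamino)ethyl, would bring the number closer to those of the ring amines in compound 1 and compound 2.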